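A few compounds are considered here, and "the series" means these few. Any claim that something is new, unique, unknown or untested is made for them only; others in the source may bear on it.

Compound 1, `CN(C)CCn1cnnc1-c1cc(Oc2ccc(NC(=O)N/N=C/c3ccc(Cl)cc3Cl)cc2F)ccn1`, in a functional assay on NCI-H460 cells (Homo sapiens) for cytotoxicity, read by MTT assay, with a stated time of 72 h (a higher number here means a weaker inhibitor, a lower number a stronger inhibitor), gives 130 nM.
Compound 2, `CN(C)CCn1cnnc1-c1cc(Oc2ccc(NC(=O)N/N=C/c3ccc(Cl)cc3)cc2F)ccn1`, gives 320 nM.

Going by the values given here, compound 2 stands with the higher of the two measured numbers in this assay; its only neighbour is compound 1, and the step of a 2.5-fold higher number from compound 1 to compound 2 (0.39 log units; beyond the scatter) came with hydrogen in place of chloro on an aromatic carbon. Compound 3, `CN(C)CCn1cnnc1-c1cc(Oc2ccc(NC(=O)N/N=C/c3cccc(O)c3)cc2F)ccn1`, differs from compound 2 by 3-hydroxyphenyl in place of 4-chlorophenyl on a carbon with a double bond to nitrogen. Among the compounds with values here, the one measured step that bears on this is a 2.5-fold higher number from compound 1 to compound 2 (0.39 log units; beyond the scatter), a modest weakening when a chloro was taken away. Within the data shown here, compound 3 now loses the last chloro and gains a hydroxyl, for which no measured compound gives guidance, so the direction is uncertain, and a further modest weakening is the expectation. Compound 3 is therefore expected to give about 500 nM, with a likely range from 150 nM to 1800 nM. The expected step of a 1.6-fold higher number from compound 2 to compound 3 (0.19 log units; within the scatter) is modest at most.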

Compound 3, half-maximal inhibitory concentration: 780 nM
For compound 3 the middle estimate is 1.6-fold (0.19 log units) below the measured one, within the range that was stated.
By their numbers in this assay, from the lowest: compound 1; then compound 2; then compound 3.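

In this assay, the new result shows that this position, the carbon with a double bond to nitrogen, responds to more than the number of chloro atoms on the ring: replacing 4-chlorophenyl with 3-hydroxyphenyl gives a 2.4-fold higher number from compound 2 to compound 3 (0.39 log units; beyond the scatter) and leaves no chloro on it. Measured against the 2,4-dichlorophenyl group, the change gives a 6.0-fold higher number from compound 1 to compound 3 (0.78 log units; beyond the scatter) and is the largest step among these compounds, so both chloro-bearing rings rank ahead of the hydroxyl-bearing ring. Nothing available explains why these numbers move as they do.

From the compounds shown here alone, compound 3 loses the chloro, gains the hydroxyl and carries its group at a different ring position in one change, so the share of each stays open. A plain phenyl ring, or a methoxy group or an amine in place of the hydroxyl, would help separate them.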